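Working notes: three measured analogues and a furan replacement

A few compounds are considered here, and "the series" means these few. Any claim that something is new, unique, unknown or untested is made for them only; others in the source may bear on it.

Measured so far:
compound 1, `CC(C)(C)c1[nH]cnc1/C=c1\[nH]c(=O)/c(=C/c2cccc(C(=O)c3ccc(F)cc3)c2)[nH]c1=O`, 3.8 nM
compound 2, `Cc1[nH]cnc1/C=c1\[nH]c(=O)/c(=C/c2cccc(C(=O)c3ccc(F)cc3)c2)[nH]c1=O`, 15.9 nM
compound 3, `O=c1[nH]/c(=C\c2ccccn2)c(=O)[nH]/c1=C\c1cccc(Oc2ccc(F)cc2)c1`, 49.1 nM

All three were run in a functional assay on NCI-H460 cells (Homo sapiens) for cytotoxicity, read by MTT assay, with a stated time of 72 h; a lower number here means a stronger inhibitor, a higher number a weaker inhibitor. Compound 3 gives the highest number of the three. Nearest to it stands compound 2 with 15.9 nM; furthest stands compound 1 with 3.8 nM.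

Among the compounds with values here, only one pair differs in a single place: the step of a 4.2-fold higher number from compound 1 to compound 2 (0.62 log units; beyond the scatter), which concerns methyl in place of tert-butyl on an aromatic carbon of the shared core of compound 1 and compound 2.

Compound 4, `Cc1ccc(/C=c2\[nH]c(=O)/c(=C/c3cccc(Oc4ccc(F)cc4)c3)[nH]c2=O)o1`, is not yet measured. It differs from compound 3 by 5-methylfuran-2-yl in place of pyridin-2-yl on a double-bonded chain carbon bound to an aromatic carbon. Within the data shown here, no measured step concerns this exchange: the one measured step touches a different group in a different part of the molecule and therefore carries no direct weight here. Compound 3 is the only close reference, so for compound 4 the working expectation is a step of a 1.0-fold higher number from compound 3 to compound 4 (0.01 log units; within the scatter), that is, none beyond the scatter in this assay. As far as these compounds go, compound 4 is thus estimated at 50 nM in this assay, with a range from 15 nM to 170 nM, the width reflecting that the exchange is untested.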

Compound 4, half-maximal inhibitory concentration: 30 nM
Compound 4: the middle estimate sits 1.7-fold (0.22 log units) above what was measured; measured number inside the range.
By their numbers in this assay, from the lowest: compound 1; then compounds 2, 4 and 3 (each within the scatter of the next, the first and the last beyond it).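

In this assay, 5-methylfuran-2-yl in place of pyridin-2-yl on a double-bonded chain carbon bound to an aromatic carbon gives a 1.6-fold lower number from compound 3 to compound 4 (0.21 log units; within the scatter), so this position tolerates the exchange of a six-membered aromatic ring with one nitrogen for a five-membered aromatic ring with one oxygen and a methyl, with no step beyond the scatter. Within the data shown here, the only earlier step, a 4.2-fold higher number from compound 1 to compound 2 (0.62 log units; beyond the scatter), lies beyond the scatter but concerns a different group in a different part of the molecule, so it said nothing about this position, for which compound 3 alone offered a single reference point. No supporting evidence bears on why the two rings read alike in this assay.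

As far as these compounds go, this one pair changes ring size, hetero atom and methyl together, so their separate contributions remain unresolved, and it is open how furan-2-yl without the methyl, or a ring carrying an amine or a carboxylic acid, would read at this place. Also open, from the compounds shown here alone, is whether the same exchange would read alike on the shared core of compound 1 and compound 2.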